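The compounds below may be only part of what the source reports. "The series", "measured", "known", "first", "only" and "open" are said of these compounds alone.

Measured in a functional assay on HL60/MX2 cells (Homo sapiens) for antiproliferative activity, read by MTT assay, with a stated time of 48 h; on this read-out lower numbers stand for stronger inhibition and higher numbers for weaker inhibition:

compound 1 , `CN(C)CCCn1c(N)c(-c2nc3ccccc3[nH]2)c2nc(C#N)c(C#N)nc21`, gives 2390 nM
compound 2 , `CCN(CC)CCCn1c(N)c(-c2nc3ccccc3[nH]2)c2nc(C#N)c(C#N)nc21`, gives 1820 nM
compound 3 , `CN(C)CCCCn1c(N)c(-c2nc3ccccc3o2)c2nc(C#N)c(C#N)nc21`, gives 960 nM

Compound 1 and compound 2 share one core and differ in a single spot: diethylamino in place of dimethylamino on a saturated chain carbon, three bonds along the chain from an aromatic nitrogen. This change gives a 1.3-fold lower number from compound 1 to compound 2 (0.12 log units; within the scatter), so the two values cannot be told apart with confidence. Compound 3 rests on a different core; how the core of compound 3 differs from the core of compound 1 is not broken down here. Compound 3 stands at the lowest of the three numbers, but its gap to compound 2 is within the usual scatter, while its gap to compound 1 is beyond it.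

Compound 4 , `CCN(CC)CCCCn1c(N)c(-c2nc3ccccc3o2)c2nc(C#N)c(C#N)nc21`, has not yet been measured in this assay. It relates to compound 3 as compound 2 relates to compound 1: diethylamino in place of dimethylamino on a saturated chain carbon, four bonds along the chain from an aromatic nitrogen. The places differ in that the exchanged group sits three bonds along the chain from the aromatic nitrogen in the first pair and four bonds along the chain in the second, so this is the same kind of change rather than the same change. Because the earlier version of it gave only a 1.3-fold lower number from compound 1 to compound 2 (0.12 log units; within the scatter), the step from compound 3 to compound 4 is expected to be small as well, about a 1.2-fold lower number from compound 3 to compound 4 (0.08 log units; within the scatter). Compound 4 is therefore estimated to reach 800 nM in this assay, with a plausible range from 350 nM to 1800 nM.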

Compound 4, half-maximal inhibitory concentration: 1720 nM
Estimate against measurement, compound 4: 2.2-fold (0.33 log units) below; measured number inside the range.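

In this assay, putting diethylamino in place of dimethylamino gives a 1.8-fold higher number from compound 3 to compound 4 (0.25 log units; within the scatter), so compound 3 and compound 4 cannot be told apart with confidence. The same exchange was already too small to read between compound 1 and compound 2, and although the two steps run in opposite directions on paper, the difference between them does not rise above the noise expected when two such steps are compared: the same change on two cores in this assay, a 1.3-fold lower number (0.12 log units; within the scatter) from compound 1 to compound 2 and a 1.8-fold higher number (0.25 log units; within the scatter) from compound 3 to compound 4, 2.4-fold (0.37 log units) apart, within the scatter of two such steps. This shows that in these two pairs the exchange leaves the number within the usual scatter on both cores, with no clear sign that the core changes its outcome, but it does not prove that the exchange has exactly the same effect on both, as a real but modest difference could stay hidden in that scatter, and two pairs are too few to support a rule for the whole series.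

Going by these compounds, it remains open whether the result would hold for a larger amine such as dipropylamino or for a smaller one such as a primary amine. A longer chain between the aromatic nitrogen and the amine is also untested by the compounds shown, so it is unknown whether the exchange would stay this small there.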